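The source may hold more compounds than are shown below. What is called first, only, known or untested is meant among the compounds shown, and "the series" means these compounds.

Of the compounds shown here, two have so far been tested in a functional assay on PC-3M cells (Homo sapiens) for cytotoxicity, read by MTT assay, with a stated time of 48 h; on this read-out higher numbers stand for weaker inhibition and lower numbers for stronger inhibition. Compound 1 `Cc1ccc(C(=O)CSc2nnc(C)n2N2C(=O)c3ccccc3C2=O)cc1` reaches only a limit of the assay: in this assay compound 1 gives > 200000 nM. Compound 2 `C=CCSc1nnc(CC)n1N1C(=O)c2ccccc2C1=O` likewise reaches only a limit, as in this assay compound 2 gives > 200000 nM. Among the compounds with values here, both values sit at the limit of > 200000 nM in this assay, at which 2 of the 2 values shown sit, so compound 2 stands exactly where every value shown stands, and no step between measured compounds can be counted. Compound 3 `CCc1nnc(SC)n1N1C(=O)c2ccccc2C1=O` differs from compound 2 by hydrogen in place of vinyl on a saturated chain carbon bound to a sulfur, which read one bond further out is allyl to methyl, allylsulfanyl to methylsulfanyl. Within the data shown here, with no measured step to lean on, no shift in this assay beyond the scatter is expected from compound 2 to compound 3 . Compound 3 is therefore estimated at 300000 nM in this assay, with a range from 100000 nM to 1000000 nM, most likely reported again only as a limit. The step this estimate means is expected to be a step that the limit leaves unreadable from compound 2 to compound 3.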

Compound 3, half-maximal inhibitory concentration: > 200000 nM
Compound 3 was reported as a limit (the forecaster's own chance of this, stated with the estimate: 85%); the middle value does not contradict the limit.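

Compound 2 and compound 3 both give only a limit, so no step between them can be read in this assay: the limit of > 200000 nM in this assay, at which 3 of the 3 values shown sit.

The compounds shown leave open which change to the shared core or its side groups, if any, would yield a measurable value in this assay.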